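This account rests on a few compounds, and the source may have more. Where it says the series, first, only, none or still open, it means among the compounds named here.

The measured compounds in an ADME assay on HUVEC cells (Homo sapiens) for antiproliferative activity, read by MTT assay, with a stated time of 48 h (a higher number here means a weaker inhibitor, a lower number a stronger inhibitor), are these. Compound 1 `Cc1cc(C)cc(-n2nncc2CN2C(=O)C3(C(C#N)=C(N)Oc4c(N)cc5nc6ccccc6nc5c43)c3ccccc32)c1` reaches only the assay limit, > 50000 nM. Compound 2 `N#CC1=C(N)Oc2c(N)cc3nc4ccccc4nc3c2C12C(=O)N(Cc1cnnn1-c1ccc(Cl)cc1Cl)c1ccccc12` reaches only the assay limit, > 50000 nM. Compound 3 `Cc1ccc(-n2nncc2CN2C(=O)C3(C(C#N)=C(N)Oc4c(N)cc5nc6ccccc6nc5c43)c3ccccc32)cc1Cl` reaches only the assay limit, > 50000 nM.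

Compound 3 thus stands where every measured compound stands: at the limit, with no number behind it, a situation summed up in the limit of > 50000 nM in this assay, at which 3 of the 3 values shown sit. The change to compound 4 `N#CC1=C(N)Oc2c(N)cc3nc4ccccc4nc3c2C12C(=O)N(Cc1cnnn1-c1c(Cl)cc(Cl)cc1Cl)c1ccccc12` is 2,4,6-trichlorophenyl in place of 3-chloro-4-methylphenyl on an aromatic nitrogen. Among the compounds with values here, the steps that bear on it are a step that the two limits leave unreadable from compound 1 to compound 2, a step that the two limits leave unreadable from compound 1 to compound 3 and a step that the two limits leave unreadable from compound 2 to compound 3; none of them can be read in size or direction because both ends of each sit at the limit (the limit of > 50000 nM in this assay, at which 3 of the 3 values shown sit). Three aryl groups on the aromatic nitrogen of the five-membered ring with three nitrogens have therefore left this assay untouched, and nothing in these data singles out a trichlorophenyl as different. The expectation for compound 4 is that it, too, will be reported at the limit, with an estimated value of 80000 nM between 40000 nM and 200000 nM. The step that the limit leaves unreadable from compound 3 to compound 4 is accordingly expected to be one that cannot be read, not a change beyond the scatter.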

Compound 4, half-maximal inhibitory concentration: 18300 nM
Compound 4: the middle estimate sits 4.4-fold (0.64 log units) above what was measured, outside the stated range (below it).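

In this assay, within the data shown here, the aryl group on the aromatic nitrogen proves to be a place where the read-out can move, which the earlier compounds could not show: 2,4,6-trichlorophenyl in place of 3-chloro-4-methylphenyl gives an at least 2.7-fold lower number from compound 3 to compound 4 (0.43 log units; beyond the scatter). A single added chloro on an aromatic carbon is enough to give an at least 2.7-fold lower number from compound 2 to compound 4 (0.43 log units; beyond the scatter), and the exchange for 3,5-dimethylphenyl gives an at least 2.7-fold lower number from compound 1 to compound 4 (0.43 log units; beyond the scatter). Each of these sizes is only a bound, and the steps among the other compounds still cannot be read: the limit of > 50000 nM in this assay, at which 3 of the 4 values shown sit.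

The compounds shown leave open whether the shift needs all three chloro groups or would also appear with 2,6-dichlorophenyl. They also leave open whether 2,4,6-trimethylphenyl or 2,4,6-trifluorophenyl in the same place would lower the number.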